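The source may report more compounds than this note shows. Statements on the series, on what has been measured and on what is new or still open speak of the compounds shown alone.

Compound 1 `COc1cc2c(Oc3ccc(NC(=O)c4nn(-c5ccccc5C(F)(F)F)c(=O)cc4C)cc3F)ccnc2cc1OCCCN1CCCCC1`: 170 nM
Compound 2 `COc1cc2c(Oc3ccc(NC(=O)c4nn(-c5ccccc5C(F)(F)F)c(=O)cc4C)cc3F)ccnc2cc1OCCCN1CCC(C)CC1`: 180 nM

Both numbers come from a functional assay on HT-29 cells (Homo sapiens) for inhibition, read by MTT assay, with a stated time of 72 h; a lower number here means a stronger inhibitor, a higher number a weaker inhibitor. Within the data shown here, compound 1 has the lower of the two numbers, but the only measured step, a 1.1-fold higher number from compound 1 to compound 2 (0.02 log units; within the scatter), is within the scatter, so the two compounds cannot be told apart. That step concerns a methyl on the saturated ring at the far end of the chain and says nothing about the aryl group attached to the aromatic nitrogen of the shared core.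

Compound 3 `COc1cc2c(Oc3ccc(NC(=O)c4nn(-c5cccc(F)c5)c(=O)cc4C)cc3F)ccnc2cc1OCCCN1CCCCC1` has not been measured. It differs from compound 1 at that aryl group: 3-fluorophenyl in place of 2-(trifluoromethyl)phenyl on an aromatic nitrogen. The trifluoromethyl is gone and the ring carries a single fluorine instead. Among the measured compounds shown here, no measured step touches this part of the molecule, so the data give no basis for a direction, and any expectation must carry a wide range. The expected step is a 1.5-fold higher number from compound 1 to compound 3 (0.17 log units; within the scatter), small and within the scatter. For compound 3 the estimate is 250 nM, with a range from 70 nM to 900 nM.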

Compound 3, half-maximal inhibitory concentration: 290 nM
The estimate for compound 3 lay 1.2-fold (0.06 log units) below the measured number; measured number inside the range.
By their numbers in this assay, from the lowest: compounds 1, 2 and 3 (each within the scatter of the next).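

In this assay, among these compounds, the first measured change to the aryl group on the aromatic nitrogen of the shared core gives a 1.7-fold higher number from compound 1 to compound 3 (0.23 log units; within the scatter) and stays within the scatter, so 2-(trifluoromethyl)phenyl, with 10 heavy atoms, and 3-fluorophenyl, with 7 heavy atoms, cannot be told apart in these cells. This single step removes the trifluoromethyl and adds a fluorine at a different ring position at the same time, so it cannot show what either part of the change does on its own. Nothing available here accounts for the similar readings of the two compounds.

The compounds shown leave open whether this position would respond to a larger change, such as a plain phenyl, a pyridine ring or a simple methyl on that nitrogen, with a difference beyond the scatter. They also leave open whether a trifluoromethyl and a fluorine would read alike if both sat at the same place on the phenyl ring, which would separate the effect of the group from that of its position.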